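Swapping the alkyne headgroup of compound 1 for a fused bicycle

The source may report more compounds than this note shows. Statements on the series, on what has been measured and on what is new or still open speak of the compounds shown alone.

Compound 1 `CCN1CCN(Cc2ccc(NC(=O)c3ccc(C)c(C#Cc4ccc(NC(=O)C5CC5)nc4)c3)cc2C(F)(F)F)CC1` belongs to a set of three measured compounds that share one core and differ only in the aromatic group attached to the triple-bonded carbon. In a functional assay on BaF3 cells (Mus musculus) for antiproliferative activity (on this read-out higher numbers stand for an effect only at larger amounts of compound and lower numbers for an effect already at smaller amounts), compound 1 gives 1800 nM, the second highest of the three numbers. Compound 2 `CCN1CCN(Cc2ccc(NC(=O)c3ccc(C)c(C#Cc4ccc(C(=O)NC)nc4)c3)cc2C(F)(F)F)CC1` gives 3980 nM, and compound 3 `CCN1CCN(Cc2ccc(NC(=O)c3ccc(C)c(C#Cc4cnc(N)cn4)c3)cc2C(F)(F)F)CC1` gives 860 nM. The steps are all modest: a 2.2-fold higher number from compound 1 to compound 2 (0.34 log units; beyond the scatter), a 2.1-fold lower number from compound 1 to compound 3 (0.32 log units; beyond the scatter), and a 4.6-fold lower number from compound 2 to compound 3 (0.67 log units; beyond the scatter).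

Compound 4 `CCN1CCN(Cc2ccc(NC(=O)c3ccc(C)c(C#Cc4cnc5[nH]cnc5c4)c3)cc2C(F)(F)F)CC1` changes the same position once more: a group of 9 heavy atoms (6 carbon, 3 nitrogen; one five-membered aromatic ring with 2 hetero atoms, one six-membered aromatic ring with 1 hetero atom) in place of a group of 12 heavy atoms (9 carbon, 2 nitrogen, 1 oxygen; one three-membered non-aromatic ring of carbon only, one six-membered aromatic ring with 1 hetero atom), on a triple-bonded carbon. For the measured compounds named here, only the step from compound 1 to compound 3 bears directly on this, since it also replaces the bulky amide-bearing headgroup with a smaller aromatic group carrying a hydrogen-bond donor, and it lowered the number modestly. A similar or somewhat larger shift downward is therefore expected for compound 4, estimated as a 3.6-fold lower number from compound 1 to compound 4 (0.56 log units; beyond the scatter). Compound 4 is expected to give about 500 nM in this assay, within a range of 150 nM to 1800 nM.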

Compound 4, half-maximal effective concentration: 60 nM
Estimate against measurement, compound 4: 8.3-fold (0.92 log units) above; the whole stated range lies above it.
By their numbers in this assay, from the lowest: compound 4; then compound 3; then compound 1; then compound 2.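

For the compounds shown here, the position on the triple-bonded carbon proves far more sensitive than the earlier compounds suggested: in this assay the change gives a 30-fold lower number from compound 1 to compound 4 (1.48 log units; beyond the scatter), along with a 14-fold lower number from compound 3 to compound 4 (1.16 log units; beyond the scatter) and a 66-fold lower number from compound 2 to compound 4 (1.82 log units; beyond the scatter). The group in compound 4 and the group it replaces in compound 1 carry the same counts of hydrogen-bond donors and acceptors, so those counts alone do not track this step. Size does not order the set either, since compound 4 has a lower number than compound 3, with its smaller group, and than compound 1 and compound 2, with their larger groups.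

No supporting data are available to explain why the fused bicycle stands so far apart. From the compounds shown here alone, whether a methyl group, an amine or a carboxylic acid added to the fused bicycle would keep or lose this low number remains open.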